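This account rests on a few compounds, and the source may have more. Where it says the series, first, only, none or still open, it means among the compounds named here.

Compound 1 `C=C1[C@H](O)CC(=C/C=C/CCC[C@@H](C)CCCC(C)(C)O)C[C@H]1O` gives 50 nM in an assay on isolated protein for displacement of a labelled ligand from vitamin D3 receptor (Rattus norvegicus); on this read-out lower numbers stand for stronger inhibition and higher numbers for weaker inhibition. Compound 2 `C=C1[C@H](O)CC(=C/C=C/C[C@H](C)C[C@@H](C)CCCC(C)(C)O)C[C@H]1O` gives 30 nM in this assay; the step of a 1.7-fold lower number from compound 1 to compound 2 (0.22 log units; within the scatter) leaves the two numbers within the scatter, so neither compound stands apart from the other. Compound 3 `C=C1[C@H](O)CC(=C/C=C/C[C@@H](C)C[C@@H](C)CCCC(C)(C)O)C[C@H]1O` differs from compound 2 only in configuration: the two compounds have the same atoms and bonds and differ only in configuration as drawn: 1 of 5 stereo elements differ; a stereocentre at a saturated chain carbon is drawn R in compound 2 and S in compound 3. Within the data shown here, no measured step here concerns a change of configuration; the single measured step, a 1.7-fold lower number from compound 1 to compound 2 (0.22 log units; within the scatter), adds a group rather than inverting a centre and offers no guide. Compound 3 is therefore expected to remain near compound 2, with a step of a 1.3-fold higher number from compound 2 to compound 3 (0.12 log units; within the scatter) of no clear direction, and an estimate of 40 nM in this assay, within 15 nM to 120 nM.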

Compound 3, inhibition constant: 10 nM
Compound 3: the middle estimate sits 4.0-fold (0.60 log units) above what was measured; the whole stated range lies above it.
By their numbers in this assay, from the lowest: compound 3; then compounds 2 and 1 (each within the scatter of the next).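

At this saturated chain carbon, the effect of the added methyl depends on its configuration. In this assay, inverting the centre gives a 3.0-fold lower number from compound 2 to compound 3 (0.48 log units; beyond the scatter), and the methyl drawn S gives a 5.0-fold lower number from compound 1 to compound 3 (0.70 log units; beyond the scatter), whereas the methyl drawn R stayed within the scatter of compound 1. This difference can be placed on the one centre alone: the fact that compounds 2 and 3 differ only in the configuration as drawn

Going by these compounds, it remains open whether an ethyl group or a hydroxyl group on this carbon would show the same dependence on configuration. The shown compounds also do not tell whether this order holds with a different chain end.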